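The compounds below may be only part of what the source reports. "The series", "measured", "known", "first", "only" and "open" are said of these compounds alone.

Compound 1 `COc1ccc(C2CC(c3ccc4ccccc4c3)=NN2C2=NC(=O)/C(=C3\C(=O)Nc4ccccc43)S2)cc1` and compound 2 `COc1ccc(C2CC(c3ccc4ccccc4c3)=NN2C2=NC(=O)/C(=C3\C(=O)Nc4ccc(Br)cc43)S2)cc1` share one core and differ in a single change: bromo in place of hydrogen on an aromatic carbon. In a functional assay on cells (Cancer cell lines, Homo sapiens) for cytotoxicity, read by sulforhodamine B assay, with a stated time of 48 h (on this read-out lower numbers stand for stronger inhibition of growth and higher numbers for weaker inhibition of growth), compound 1 gives 32800 nM, while compound 2 gives 990 nM, so the step of a 33-fold lower number from compound 1 to compound 2 (1.52 log units; beyond the scatter) is a large one. Compound 3 `CN(C)c1ccc(C2CC(c3ccccc3)=NN2C2=NC(=O)/C(=C3\C(=O)Nc4ccccc43)S2)cc1` carries a different core; how it differs from compound 1 is not broken down here. In this assay compound 3 gives 20300 nM, which lies within the scatter of compound 1. Compound 4 `CN(C)c1ccc(C2CC(c3ccccc3)=NN2C2=NC(=O)/C(=C3\C(=O)Nc4ccc(Br)cc43)S2)cc1` is to compound 3 what compound 2 is to compound 1, with the same change in the same place: bromo in place of hydrogen on an aromatic carbon. Because a 33-fold lower number from compound 1 to compound 2 (1.52 log units; beyond the scatter) was large, the step of a 14-fold lower number from compound 3 to compound 4 (1.13 log units; beyond the scatter) is expected to be sizeable as well, though somewhat smaller to allow for the different core. The estimate for compound 4 in this assay is therefore 1500 nM.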

Compound 4, concentration for total growth inhibition: 510 nM
The estimate for compound 4 lay 2.9-fold (0.47 log units) above the measured number, within the range that was stated.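

In this assay, bromo in place of hydrogen on an aromatic carbon again gives a large step, a 40-fold lower number from compound 3 to compound 4 (1.60 log units; beyond the scatter). Set beside the earlier step, the change carries over from one core to the other with no difference that can be told apart: the same change on two cores in this assay, a 33-fold lower number (1.52 log units; beyond the scatter) from compound 1 to compound 2 and a 40-fold lower number (1.60 log units; beyond the scatter) from compound 3 to compound 4, 1.2-fold (0.08 log units) apart, within the scatter of two such steps. This shows that the step kept its size on these two cores in this one assay, but it does not show that it would do so on any other core, or why the step occurs.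

The compounds shown leave open what chloro, a methyl group or an amine would do in place of the bromo. Also open, as far as these compounds go, is whether bromo on another carbon of the same ring would give a step of this size.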